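The source may hold more compounds than are shown below. What is called first, only, known or untested is meant among the compounds shown, and "the series" means these compounds.

Measured compounds:
Compound 1 `CCCNNC(=O)c1ccc(CNC(=O)c2cc3ccccc3o2)cc1` — in an assay on isolated protein for inhibition of protein deacetylase HDAC6 (Homo sapiens), read by fluorescence, with a stated time of 2 h (on this read-out lower numbers stand for stronger inhibition and higher numbers for weaker inhibition), compound 1 gives > 10000 nM, which is a limit of the assay and not a number.
Compound 2 `CCCNNC(=O)c1ccc(CNC(=O)c2cc3cc(O)ccc3o2)cc1` — in this assay compound 2 gives > 10000 nM, again a limit.
Compound 3 `C=CCOc1ccc2oc(C(=O)NCc3ccc(C(=O)NNCCC)cc3)cc2c1` — in this assay compound 3 gives > 10000 nM, also a limit.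

Compound 3 therefore stands nowhere in particular on a scale: it shares the limit with both other compounds, and no order among the three can be read. The measured steps, a step that the two limits leave unreadable from compound 1 to compound 2, a step that the two limits leave unreadable from compound 1 to compound 3 and a step that the two limits leave unreadable from compound 2 to compound 3, are all unreadable in size, because every value sits at the limit of > 10000 nM in this assay, at which 3 of the 3 values shown sit.

Compound 4 `CCCNNC(=O)c1ccc(CNC(=O)c2cc3cc(F)ccc3o2)cc1` differs from compound 3 by fluoro in place of allyloxy on an aromatic carbon. The three measured steps bear on it directly, since each of them also varies the group on an aromatic carbon of the shared core, yet none gives a readable size. Hydrogen, hydroxy and allyloxy at that carbon all leave the compound at the limit in this assay; nothing shown suggests fluoro will behave differently. The expected step that the limit leaves unreadable from compound 3 to compound 4 is thus not a readable change, and compound 4 is expected to sit at the limit again in this assay, estimated at 15000 nM within 4000 nM to 60000 nM.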

Compound 4, half-maximal inhibitory concentration: > 10000 nM
Compound 4 gave a limit, no number; the forecaster's own chance of this, stated with the estimate: 85%; the middle value is on the limit's open side.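

Compound 4 gives a limit and not a number in this assay, and its steps from compound 1, compound 2 and compound 3 cannot be read: the limit of > 10000 nM in this assay, at which 4 of the 4 values shown sit.

The compounds shown leave open whether any group on this aromatic carbon of the shared core can give a readable value in this assay, and how far each of the four compounds lies beyond the limit.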